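Straightening the Chain of Compound 2

The source may hold more compounds than are shown below. What is called first, only, known or untested is meant among the compounds shown, and "the series" means these compounds.

Measured in an ADME assay on MDCK cells (Canis lupus familiaris) for cytotoxicity, read by crystal violet staining, with a stated time of 48 h; a higher number here means that more compound is tolerated, a lower number that less compound is tolerated:
Compound 1 `COc1c(CCCC(C)C)coc(=O)c1C`: 2000000 nM
Compound 2 `COc1c(CCCCC(C)C)coc(=O)c1C`: 1880000 nM
Compound 3 `Cc1c(O)c(CCCCC(C)C)coc1=O`: 1290000 nM

On these numbers, compound 2, at 1880000 nM, lies within the scatter of both compound 1 and compound 3. Compound 4 `CCCCCCCc1coc(=O)c(C)c1OC` has the same atoms as compound 2, joined differently: propyl in place of isopropyl on a saturated chain carbon, four bonds along the chain from an aromatic carbon. The same difference, cut one bond further out, reads isopentyl to pentyl.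

Going by the values given here, no measured pair makes this exact change, so the evidence is indirect. The closest step alters the same chain, a 1.1-fold lower number from compound 1 to compound 2 (0.03 log units; within the scatter). The other step concerns a different place, a methyl on an oxygen on an aromatic ring, a 1.5-fold lower number from compound 2 to compound 3 (0.16 log units; within the scatter). Neither step leaves the scatter, so no change beyond the scatter is expected in this assay. The estimate amounts to an expected step of a 1.0-fold lower number from compound 2 to compound 4 (0.02 log units; within the scatter). For compound 4 the estimated value is 1800000 nM, with an expected range from 1100000 nM to 2700000 nM.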

Compound 4, half-maximal cytotoxic concentration: 2230000 nM
For compound 4 the middle estimate is 1.2-fold (0.09 log units) below the measured one; the range from low to high includes it.
By their numbers in this assay, from the lowest: compounds 3, 2, 1 and 4 (each within the scatter of the next).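

Compound 4 carries propyl in place of isopropyl on a saturated chain carbon, four bonds along the chain from an aromatic carbon, and in this assay this change reads as a 1.2-fold higher number from compound 2 to compound 4 (0.07 log units; within the scatter). Measured against the shorter branched chain, butyl in place of isopropyl gives a 1.1-fold higher number from compound 1 to compound 4 (0.05 log units; within the scatter), so among these compounds neither removing the branch nor altering the chain length takes the number outside the scatter. Nothing measured here accounts for how closely these numbers sit together.

The compounds shown leave open whether an amine or a carboxylic acid on this chain, or a longer chain, would also stay within the scatter. They also leave open whether hydrogen in place of methyl on an oxygen on an aromatic ring would read the same in the unbranched chain of compound 4.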